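The source may hold more compounds than are shown below. What is called first, only, known or untested is meant among the compounds shown, and "the series" means these compounds.

Within the data shown here, compound 2 `c1coc(-c2ccccc2OCC2=NCCN2)c1` gives 10 nM in a functional assay for activation of Alpha-1B adrenergic receptor (Homo sapiens), read by calcium flux (on this read-out higher numbers stand for an effect only at larger amounts of compound and lower numbers for an effect already at smaller amounts), the only number. Compound 1 `c1ccc(-c2ccncc2)c(OCC2=NCCN2)c1` returns only a limit of the assay, < 100000 nM. Compound 3 `Cc1cnsc1-c1ccccc1OCC1=NCCN1` likewise returns only a limit, < 100000 nM. Because of the limit of < 100000 nM in this assay, at which 2 of the 3 values shown sit, every measured step is unreadable: a step that the limit leaves unreadable from compound 1 to compound 2, a step that the limit leaves unreadable from compound 2 to compound 3, and a step that the two limits leave unreadable from compound 1 to compound 3. Compound 4 `Cn1nccc1-c1ccccc1OCC1=NCCN1` arises from compound 2 by 1-methyl-1H-pyrazol-5-yl in place of furan-2-yl on an aromatic carbon. Among the measured compounds shown here, the closest precedent, a step that the limit leaves unreadable from compound 2 to compound 3, exchanges one five-membered aromatic ring for another yet carries no readable size, so neither direction nor magnitude can be taken from the series. In this assay compound 4 is therefore expected at 30 nM, with a wide range of 3 nM to 300 nM. The estimated step, a 3.0-fold higher number from compound 2 to compound 4 (0.48 log units; beyond the scatter), is expected to remain within the scatter.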

Compound 4, half-maximal effective concentration: < 100000 nM
Compound 4: no number, only a limit (the forecaster's own chance of this, stated with the estimate: 20%); the middle value does not contradict the limit.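

No step linking compound 4 to compound 1, compound 2 or compound 3 can be read: the limit of < 100000 nM in this assay, at which 3 of the 4 values shown sit.

The compounds shown leave open how large any step away from the furan-2-yl of compound 2 is in this assay.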